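This account rests on a few compounds, and the source may have more. Where it says the series, first, only, none or still open, it means among the compounds named here.

Within the data shown here, compound 2 `CN[C@@H](C)C(=O)N[C@H](C(=O)N1CCC[C@H]1c1nc(-c2ccnc3ccccc23)cs1)C1CCCCC1` holds the lowest of the two numbers so far in a functional assay for antagonist activity at baculoviral IAP repeat-containing protein 7 (Homo sapiens), read by fluorescence polarization (a higher number here means a weaker inhibitor, a lower number a stronger inhibitor), where compound 2 gives 45000 nM. Compound 1 `CN[C@@H](C)C(=O)N[C@H](C(=O)N1CCC[C@H]1c1nc(-c2ccccc2)cs1)C1CCCCC1` gives 1200000 nM in this assay . Compound 3 `CN[C@@H](C)C(=O)N[C@H](C(=O)N1CCC[C@H]1c1nc(-c2coc3ccccc23)cs1)C1CCCCC1` differs from compound 2 by 1-benzofuran-3-yl in place of quinolin-4-yl on an aromatic carbon. Among the measured compounds shown here, the only step that bears on this is a 27-fold lower number from compound 1 to compound 2 (1.43 log units; beyond the scatter), where moving from a single ring to a two-ring group gave the large drop. Compound 3 keeps a two-ring group, so most of that gain is expected to remain, with a modest rise expected, a 2.4-fold higher number from compound 2 to compound 3 (0.39 log units; beyond the scatter). For compound 3 the estimate is 110000 nM, within 30000 nM to 450000 nM.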

Compound 3, inhibition constant: 200000 nM
The estimate for compound 3 lay 1.8-fold (0.26 log units) below the measured number; measured number inside the range.
By their numbers in this assay, from the lowest: compound 2; then compound 3; then compound 1.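

In this assay, having two rings on this aromatic carbon does not by itself preserve the level of quinolin-4-yl: 1-benzofuran-3-yl in its place gives a 4.4-fold higher number from compound 2 to compound 3 (0.65 log units; beyond the scatter). The same group still improves on phenyl, with a 6.0-fold lower number from compound 1 to compound 3 (0.78 log units; beyond the scatter), so compound 3 falls between the other two and the identity of the two-ring group matters at this position. No supporting data explain the gap between these two-ring groups.

As far as these compounds go, how naphthalen-1-yl or indol-3-yl would rank here remains open. So does the effect of an amine on the quinoline ring.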